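The compounds below may be only part of what the source reports. "The series", "measured", "known", "first", "only" and "open" are said of these compounds alone.

Measured compounds in a physicochemical assay for solubility; a lower number here means a less soluble compound, a higher number a more soluble compound:
compound 1 `CNC(=O)c1cc(C(=O)NC2CC2)cn(Cc2ccc(OC)cc2)c1=O`, >= 143 ug/mL, a limit of the assay, not a number.
compound 2 `CNC(=O)c1ccc(=O)n(Cc2ccccc2)c1`, >= 108 ug/mL, a limit of the assay.
compound 3 `CNC(=O)c1cc(C(=O)NC2CCC2)cn(Cc2cccc(NC)c2)c1=O`, >= 155 ug/mL, a limit of the assay.

Compound 1 therefore stands at a limit rather than at a number, and the two further values are limits as well (the limit of >= 108 ug/mL in this assay, at which 1 of the 3 values shown sits, (the limit of >= 143 ug/mL in this assay, at which 1 of the 3 values shown sits), (the limit of >= 155 ug/mL in this assay, at which 1 of the 3 values shown sits)). Within the data shown here, no measured pair differs in only one place, so no step within this set can be sized.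

Compound 4 `CNC(=O)c1cc(C(=O)NC2CC2)cn(Cc2cccc3c2CCN3)c1=O` is not yet measured. Its change from compound 1 is 2,3-dihydro-1H-indol-4-yl in place of 4-methoxyphenyl on a saturated chain carbon bound to an aromatic nitrogen. Since compound 1 sits at the limit of >= 143 ug/mL in this assay, at which 1 of the 3 values shown sits, the step that the limit leaves unreadable from compound 1 to compound 4 is expected to stay within the scatter. For compound 4 the expected result is 150 ug/mL, within 60 ug/mL to 300 ug/mL, and most likely reported again as a limit.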

Compound 4, solubility: >= 184 ug/mL
Compound 4 was reported as a limit; the forecaster's own chance of this, stated with the estimate: 70%; middle value at least 1.2-fold (0.08 log units) away from the limit.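

In this assay compound 4 gives >= 184 ug/mL, a limit of the assay. Compound 1 gives >= 143 ug/mL, also a limit, so the step between compound 1 and compound 4 cannot be read. The compounds shown leave open where the actual solubility of any of them lies.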